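Triazole phenol series: cytotoxicity and the methoxy analogue

The source may report more compounds than this note shows. Statements on the series, on what has been measured and on what is new or still open speak of the compounds shown alone.

Compound 1 `COc1ccc(-c2cn(C[C@H]3c4c(ccc(OS(=O)(=O)c5ccc(C)cc5)c4C)[C@@H]4CC[C@@]5(C)C[C@]43CC5=O)nn2)cc1` carries a tosylate on the phenol oxygen and a 4-methoxyphenyl on the triazole. In a functional assay on SMMC-7721 cells (Homo sapiens) for cytotoxicity, read by MTT assay, with a stated time of 4 days (a higher number here means a weaker inhibitor, a lower number a stronger inhibitor), compound 1 gives > 20000 nM, which is a limit of the assay and not a number. Compound 2 `Cc1c(O)ccc2c1[C@H](Cn1cc(-c3ccc(C(F)(F)F)cc3)nn1)[C@@]13CC(=O)[C@@](C)(CC[C@@H]21)C3` has the free phenol and a 4-(trifluoromethyl)phenyl on the triazole. In this assay compound 2 gives > 20000 nM, again a limit rather than a measured value. Compound 2 therefore sits at the limit of > 20000 nM in this assay, at which 2 of the 2 values shown sit, and no order between the two can be drawn. Compound 3 `COc1ccc(-c2cn(C[C@H]3c4c(ccc(O)c4C)[C@@H]4CC[C@@]5(C)C[C@]43CC5=O)nn2)cc1` differs from compound 2 by methoxy in place of trifluoromethyl on an aromatic carbon. The 4-methoxyphenyl is already present in compound 1, which reaches only > 20000 nM in this assay. Going by the values given here, with no measured step available, the step is expected to be a step that the limit leaves unreadable from compound 2 to compound 3, nothing beyond the scatter, most likely ending at the limit again. Compound 3 is estimated at 30000 nM, within a range from 12000 nM to 80000 nM.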

Compound 3, half-maximal inhibitory concentration: > 20000 nM
Compound 3: a limit, no number (the forecaster's own chance of this, stated with the estimate: 80%); the middle value is on the limit's open side.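

The steps to compound 3 from compound 2 and from compound 1 cannot be read, because all three compounds give a limit of the assay and not a number: the limit of > 20000 nM in this assay, at which 3 of the 3 values shown sit.

The compounds shown leave open whether either change, on the triazole's aryl group or on the phenol oxygen, has any effect in this assay.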